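The source may hold more compounds than are shown below. What is called first, only, known or untested is meant among the compounds shown, and "the series" means these compounds.

Compound 1 `Cc1ccc(S(=O)(=O)Cc2nc(Nc3ccc(F)cc3)c3ccccc3n2)cc1` was tested in a functional assay on K562 cells (Homo sapiens) for cytotoxicity, read by flow cytometry, with a stated time of 72 h; on this read-out higher numbers stand for weaker inhibition and lower numbers for stronger inhibition. In this assay compound 1 gives only a limit of the assay, > 20000 nM. Compound 2 `Cc1ccc(S(=O)(=O)Cc2nc(Nc3cccc(Br)c3)c3ccccc3n2)cc1` carries 3-bromophenyl in place of 4-fluorophenyl on a nitrogen on an aromatic ring. In this assay compound 2 likewise reaches only a limit, > 15000 nM. The step that the two limits leave unreadable from compound 1 to compound 2 therefore cannot be read. Compound 3 `CC(C)=Cc1nc(Nc2ccc(F)cc2)c2cc([N+](=O)[O-])ccc2n1` rests on a different core; how that core differs from the core of compound 1 is not broken down here. In this assay compound 3 again gives a limit, > 62000 nM. Compound 4 `CC(C)=Cc1nc(Nc2cccc(Br)c2)c2cc([N+](=O)[O-])ccc2n1` is not yet measured and differs from compound 3 by 3-bromophenyl in place of 4-fluorophenyl on a nitrogen on an aromatic ring, the same change as from compound 1 to compound 2, at the same place. Because compound 3 sits at the limit of > 62000 nM in this assay, at which 1 of the 3 values shown sits, and the earlier step is unreadable, the step of a number no higher from compound 3 to compound 4 (the limit leaves the size open) is expected to be small. Compound 4 is estimated at 62000 nM, most likely once more a limit.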

Compound 4, half-maximal inhibitory concentration: > 62000 nM
Compound 4: only a limit was reported; the forecaster's own chance of this, stated with the estimate: 85%; the middle value lies on the limit itself.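

Compound 3 and compound 4 both sit at an assay limit, as do compound 1 and compound 2, so neither swap of 4-fluorophenyl for 3-bromophenyl gives a step that can be read. The compounds shown leave open whether this change alters cytotoxicity on either core.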